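Methoxy on the anilide ring of the thioether series

The source may report more compounds than this note shows. Statements on the series, on what has been measured and on what is new or still open speak of the compounds shown alone.

Compound 1 `CNC(=O)CCSc1ccc2c(/C=C/c3ccccn3)n[nH]c2c1` gives only a limit, > 10000 nM, in an ADME assay on BaF3 cells (Mus musculus) for antiproliferative activity, read by CCK-8 assay, with a stated time of 72 h; on this read-out higher numbers stand for weaker inhibition of growth and lower numbers for stronger inhibition of growth. For compound 1 this value is the limit of the assay (the limit of > 10000 nM in this assay, at which 1 of the 2 values shown sits). Among the compounds with values here, compound 2 `O=C(CCSc1ccc2c(/C=C/c3ccccn3)n[nH]c2c1)Nc1ccccc1` gives 690 nM in this assay, the only number among the values shown. Within the data shown here, the one measured step, an at least 14-fold lower number from compound 1 to compound 2 (1.16 log units; beyond the scatter), replaced methyl with phenyl on an amide-type nitrogen and was large. Compound 3 `COc1cccc(NC(=O)CCSc2ccc3c(/C=C/c4ccccn4)n[nH]c3c2)c1` differs from compound 2 by methoxy in place of hydrogen on an aromatic carbon, placed on an aromatic carbon of a six-membered aromatic ring of carbon only. The measured step concerns the same amide substituent but a much larger replacement, so it bears only loosely on a methoxy addition; no step shown tests a substituent on this ring. The expected step from compound 2 to compound 3 is a 1.3-fold lower number from compound 2 to compound 3 (0.10 log units; within the scatter), within the scatter. Compound 3 is therefore estimated at 550 nM in this assay, between 200 nM and 1500 nM.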

Compound 3, concentration for 50% growth inhibition: 3840 nM
Compound 3: middle estimate off by 7.0-fold (0.84 log units), on the low side; the measured number lies above the stated range.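

In this assay, the anilide ring proves sensitive to a small addition: methoxy in place of hydrogen on an aromatic carbon, meta to a large group, gives a 5.6-fold higher number from compound 2 to compound 3 (0.75 log units; beyond the scatter). Part of the advantage of the aryl amide over the methyl amide still remains, with an at least 2.6-fold lower number from compound 1 to compound 3 (0.41 log units; beyond the scatter). Compound 1 carries a limit, so that last step is only a bound: the limit of > 10000 nM in this assay, at which 1 of the 3 values shown sits.

The compounds shown leave open whether this weakening belongs to methoxy as a group or to this place on the ring, and they give no cause for it. A hydroxyl group or a chlorine atom on the same carbon, or methoxy on another carbon of the ring, would separate these two readings.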